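Benzoyl for (benzyloxy)methoxy on the shared core

The source may hold more compounds than are shown below. What is called first, only, known or untested is meant among the compounds shown, and "the series" means these compounds.

Measured so far:
compound 1 `N#Cc1ccn2c(-c3ccccc3)c(-c3ccccc3)c(OCOCc3ccccc3)c2c1`: 39000 nM
compound 2 `N#Cc1ccn2c(-c3ccccc3)c(-c3ccccc3)c(OCc3ccc(F)cc3)c2c1`: "not determined" (no result reported)
compound 3 `N#Cc1ccn2c(-c3ccccc3)c(-c3ccccc3)c(OCOC(COCc3ccccc3)COCc3ccccc3)c2c1`: "not determined" (no result reported)

Within the data shown here, in an assay for inhibition of Polyunsaturated fatty acid lipoxygenase ALOX15 (Oryctolagus cuniculus) (on this read-out higher numbers stand for weaker inhibition and lower numbers for stronger inhibition), compound 1 gives 39000 nM and is the only member of the series with a number; compound 2 and compound 3 carry no result in this assay, so compound 1 stands alone and cannot be placed against any neighbour. Among the measured compounds shown here, no two measured compounds differ in one place, so no step size is known.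

Compound 4 `N#Cc1ccn2c(-c3ccccc3)c(-c3ccccc3)c(C(=O)c3ccccc3)c2c1` is the next entry. Relative to compound 1 the change is benzoyl in place of (benzyloxy)methoxy on an aromatic carbon, on an aromatic carbon of a five-membered aromatic ring with 1 nitrogen, part of a fused or bridged system of two rings.

For the measured compounds named here, with no measured step to lean on, the expectation for compound 4 rests on compound 1 alone at 39000 nM. The step from compound 1 is expected to be small, a 1.6-fold lower number from compound 1 to compound 4 (0.19 log units; within the scatter), toward somewhat stronger inhibition but not clearly beyond the scatter. Compound 4 is therefore estimated at 25000 nM, with a range from 6000 nM to 90000 nM.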

Compound 4, half-maximal inhibitory concentration: 43000 nM
Beside the measured number, compound 4's estimate is 1.7-fold (0.24 log units) below it; the range from low to high includes it.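

In this assay, among these compounds, benzoyl in place of (benzyloxy)methoxy on an aromatic carbon gives a 1.1-fold higher number from compound 1 to compound 4 (0.04 log units; within the scatter), the first readable step and one within the scatter. At this position of the shared core, the read-out therefore does not separate the two groups, although the oxygen-bearing chain of (benzyloxy)methoxy gives way to a carbonyl and only the six-membered aromatic ring of carbon is common to both. Nothing available accounts for this lack of separation.

From the compounds shown here alone, both groups carry that aromatic ring, so it remains open whether a group without it, such as an amine or a carboxylic acid, would move the number beyond the scatter on this carbon. Also open, going by these compounds, is whether the same exchange would read alike with the phenyl groups of the shared core replaced.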